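The source may hold more compounds than are shown below. What is called first, only, known or untested is meant among the compounds shown, and "the series" means these compounds.

Measured so far in a functional assay on PC-3 cells (Homo sapiens), read by MTT assay, with a stated time of 48 h; on this read-out lower numbers stand for stronger inhibition and higher numbers for weaker inhibition:
compound 1 `CCn1c(C(=O)NCCN(C)C)ccc1C(CC)(CC)c1ccc(OCC(=O)C(C)(C)C)c(C)c1`: 2300 nM
compound 2 `CCn1c(C(=O)NCCCN(C)C)ccc1C(CC)(CC)c1ccc(OCC(=O)C(C)(C)C)c(C)c1`: 1600 nM
compound 3 `CCn1c(C(=O)NCCCN(C)C)ccc1C(CC)(CC)c1ccc(OCC(O)C(C)(C)C)c(C)c1`: 3100 nM

Compound 3 carries the highest of the three numbers, yet its gaps to compound 1 and to compound 2 are both within the scatter, so the three sit together. Compound 4 `CCn1c(C(=O)N(CCC#N)CCC#N)ccc1C(CC)(CC)c1ccc(OCC(O)C(C)(C)C)c(C)c1` differs from compound 3 by a group of 9 heavy atoms (6 carbon, 3 nitrogen; no ring) in place of a group of 7 heavy atoms (5 carbon, 2 nitrogen; no ring), on a carbonyl carbon, on a carbonyl carbon whose other neighbour is an aromatic carbon. Among the measured compounds shown here, only the step of a 1.4-fold lower number from compound 1 to compound 2 (0.16 log units; within the scatter) touches the same amide side; the step of a 1.9-fold higher number from compound 2 to compound 3 (0.29 log units; within the scatter) lies at the aryl ether end. Both were within the scatter. Neither step removes the (3-(dimethylamino)propyl)amino group outright, so the present change is not covered; a weakening step is expected, a 1.6-fold higher number from compound 3 to compound 4 (0.21 log units; within the scatter). Compound 4 is expected at 5000 nM, between 1500 nM and 15000 nM.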

Compound 4, half-maximal inhibitory concentration: 7800 nM
For compound 4 the middle estimate is 1.6-fold (0.19 log units) below the measured one; low and high end bracket the measured number.
By their numbers in this assay, from the lowest: compounds 2, 1 and 3 (each within the scatter of the next); then compound 4.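

In this assay, the amide side now gives a step beyond the scatter, a 2.5-fold higher number from compound 3 to compound 4 (0.40 log units; beyond the scatter), whereas changing the chain length there from compound 1 to compound 2 did not. This single change replaces the (3-(dimethylamino)propyl)amino group, including its dimethylamino end and amide hydrogen, with a nitrile-bearing group that has no hydrogen-bond donor. No measurement here accounts for the step.

The compounds shown leave open which part of the exchange goes with the higher number. A (2-cyanoethyl)amino group, which keeps the amide hydrogen, would separate these parts.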